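The compounds below may be only part of what the source reports. "The series", "measured", "known", "first", "only" and "open" are said of these compounds alone.

Measured compounds: compound 1, `COc1ccc(C(=O)/C=C/c2cc3ccccc3[nH]c2=O)cc1`; compound 2, `O=C(/C=C/c1cc2ccccc2[nH]c1=O)c1ccc(O)cc1`.

In an ADME assay on BT-549 cells (Homo sapiens) for cytotoxicity, read by sulforhodamine B assay, with a stated time of 24 h (a higher number here means that more compound is tolerated, a lower number that less compound is tolerated), compound 1 gives 46300 nM. Compound 2 reaches only a limit in this assay, > 100000 nM. The step from compound 1 to compound 2, hydrogen in place of methyl on an oxygen on an aromatic ring, reads an at least 2.1-fold higher number from compound 1 to compound 2 (0.33 log units; beyond the scatter) and is bounded by the limit of > 100000 nM in this assay, at which 1 of the 2 values shown sits. Compound 3, `O=C(/C=C/c1cc2ccccc2[nH]c1=O)c1ccc(Cl)cc1`, differs from compound 2 by chloro in place of hydroxy on an aromatic carbon, on an aromatic carbon para to a large group. Among the compounds with values here, no measured step covers chloro at that place, so the expectation is wide. Compound 3 is expected at 60000 nM, within 20000 nM to 150000 nM, an expected step of an at least 1.6-fold lower number from compound 2 to compound 3 (0.22 log units; that floor lies within the scatter).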

Compound 3, concentration lethal to 50% of the cells: 97600 nM
Beside the measured number, compound 3's estimate is 1.6-fold (0.21 log units) below it, and the stated range covers the measured number.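

In this assay, chloro in place of methoxy reads a 2.1-fold higher number from compound 1 to compound 3 (0.32 log units; beyond the scatter), so at this place, para to a large group, the higher number does not depend on a hydroxy. The step from hydroxy to chloro reads an at least 1.0-fold lower number from compound 2 to compound 3 (0.01 log units; that floor lies within the scatter), and no order follows from it, since the value of compound 2 is a limit of the assay: the limit of > 100000 nM in this assay, at which 1 of the 3 values shown sits.

As far as these compounds go, whether an amine or a carboxylic acid at this place would give a number as high remains open. The compounds shown also leave open how a change elsewhere on the shared core would read.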